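A few compounds are considered here, and "the series" means these few. Any claim that something is new, unique, unknown or untested is made for them only; others in the source may bear on it.

In a functional assay on KB cells (Homo sapiens) for inhibition (a lower number here means a stronger inhibitor, a higher number a weaker inhibitor), compound 3 `Cc1ccc(N2C(=O)[C@@H](n3cc(-c4ccccc4)nn3)[C@H]2/C=C/c2ccccc2)cc1` gives 89200 nM. Its closest neighbour is compound 2 `O=C1[C@@H](n2cc(-c3ccccc3)nn2)[C@@H](/C=C/c2ccccc2)N1c1ccccc1`, which gives 91300 nM in this assay; the step of a 1.0-fold lower number from compound 2 to compound 3 (0.01 log units; within the scatter) places the two within the scatter of one another, so neither can be called the stronger. Compound 1 `COC(=O)c1nnn([C@@H]2C(=O)N(c3ccc(C)cc3)[C@@H]2/C=C/c2ccccc2)c1C(=O)OC` has "not determined" (no result reported) in this assay, and no other number is known, so compound 3 stands as one of two near-identical weak inhibitors. Compound 4 `O=C1[C@@H](n2cc(-c3ccccc3)nn2)[C@@H](/C=C/c2ccccc2)N1C1CCCCC1` differs from compound 3 by cyclohexyl in place of 4-methylphenyl on an amide-type nitrogen in a ring. Within the data shown here, the only measured step, from compound 2 to compound 3, concerns a methyl on an aromatic carbon and did not move the number beyond the scatter; no measured step exchanges the aromatic ring on this nitrogen for a non-aromatic one, so the direction of the change is uninformed by the data. The expected step of a 1.0-fold higher number from compound 3 to compound 4 (0.00 log units; within the scatter) is therefore set at none beyond the scatter, with a wide range. Compound 4 is estimated at 90000 nM, between 30000 nM and 270000 nM.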

Compound 4, half-maximal inhibitory concentration: 8360 nM
Compound 4: middle estimate off by 11-fold (1.03 log units), on the high side, outside the stated range (below it).
By their numbers in this assay, from the lowest: compound 4; then compounds 3 and 2 (each within the scatter of the next).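

In this assay, this position on the amide-type nitrogen in a ring turned out to respond strongly to the group it carries: the change gives an 11-fold lower number from compound 3 to compound 4 (1.03 log units; beyond the scatter), and the matching exchange for phenyl gives an 11-fold lower number from compound 2 to compound 4 (1.04 log units; beyond the scatter). The earlier step, a methyl on the aromatic ring, had left the number within the scatter (a 1.0-fold lower number from compound 2 to compound 3 (0.01 log units; within the scatter)), so among these compounds it is the exchange of the whole aromatic ring for cyclohexyl that separates compound 4 from compound 2 and compound 3. Nothing measured here accounts for this difference. 

Going by these compounds, it remains open whether the gain belongs to cyclohexyl itself or to non-aromatic groups more widely, such as cyclopentyl, an open hexyl chain or a piperidine ring. On these data alone, it is also open whether the exchange would act alike with methyl ester groups in place of the phenyl on the shared core.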